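The compounds below may be only part of what the source reports. "The series", "measured", "known", "first", "only" and "open" are said of these compounds alone.

Measured compounds:

Compound 1, `COc1ccc(S(=O)(=O)N2CCCC(Cn3ccnc3)C2)cc1F`: 14 nM
Compound 2, `COc1ccc(S(=O)(=O)N2CCCC(Cn3ccnc3)C2)cc1OC`: 42 nM
Compound 3, `CS(=O)(=O)c1ccc(S(=O)(=O)N2CCCC(Cn3ccnc3)C2)cc1`: 48 nM

Of the compounds shown here, three sharing one core have been tested in an assay on isolated protein for inhibition of Aromatase (Homo sapiens), read by fluorescence; on this read-out lower numbers stand for stronger inhibition and higher numbers for weaker inhibition. Among them compound 1 gives the lowest number, and its steps to both of the other two lie beyond the usual scatter, so it is the strongest inhibitor of the three. For the measured compounds named here, the one single-point change among the measured compounds is a 3.0-fold higher number from compound 1 to compound 2 (0.48 log units; beyond the scatter), a methoxy in place of a fluoro on the aromatic ring, which weakened inhibition modestly. Compound 3 carries a methylsulfonyl group on its aromatic ring instead, and in this assay compound 3 gives 48 nM, a number of similar size to that of compound 2.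

Compound 4, `O=S(=O)(c1ccc(OC2CCCC2)c(F)c1)N1CCCC(Cn2ccnc2)C1`, is not yet measured. It differs from compound 1 by cyclopentyl in place of methyl on an oxygen on an aromatic ring. Going by the values given here, no measured step touches this oxygen-bound group; the step from compound 1 to compound 2 shows only that enlarging one ring substituent raised the number modestly, and it concerns a different position. The expectation is therefore a step of modest size at most, leaning toward a somewhat higher number, though one within the scatter cannot be excluded. Compound 4 is expected to give about 25 nM, with a range from 8 nM to 80 nM. The estimated step is a 1.8-fold higher number from compound 1 to compound 4 (0.25 log units; within the scatter).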

Compound 4, half-maximal inhibitory concentration: 22 nM
The estimate for compound 4 lay 1.1-fold (0.06 log units) above the measured number, and the stated range covers the measured number.
By their numbers in this assay, from the lowest: compounds 1, 4, 2 and 3 (each within the scatter of the next, the first and the last beyond it).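

For the compounds shown here, this is the first measured change to the group on this oxygen on the aromatic ring: in this assay, going from methoxy to cyclopentyloxy gives a 1.6-fold higher number from compound 1 to compound 4 (0.20 log units; within the scatter) and so stays within the usual scatter. Compound 1 and compound 4 therefore cannot be told apart on this read-out, even though a methyl of 1 heavy atom has given way to a cyclopentyl of 5 heavy atoms, with a ring added, so in this one example the larger group is tolerated at this position. No measurement shown here bears on the reason for this result.

The compounds shown leave open how far this tolerance extends, since a single replacement cannot say whether a longer chain such as hexyl, a phenyl ring, a carboxylic acid or an amine on the same oxygen would also stay within the scatter of compound 1. They also leave open whether cyclopentyl on this oxygen would give a similar result in a compound that lacks the fluoro group on the aromatic ring.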